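This account rests on a few compounds, and the source may have more. Where it says the series, first, only, none or still open, it means among the compounds named here.

Of the compounds shown here, three built on one shared core have been measured in a functional assay on CHO-K1 cells for antagonist activity at transient receptor potential cation channel subfamily V member 1 (Homo sapiens), read by FLIPR; on this read-out lower numbers stand for stronger inhibition and higher numbers for weaker inhibition. Compound 1 `CCCCNc1nc(C(F)(F)F)ccc1CNC(=O)C(C)c1ccc(NS(C)(=O)=O)c(F)c1` gives 293 nM. Compound 2 `CC(C(=O)NCc1ccc(C(F)(F)F)nc1N(C)C)c1ccc(NS(C)(=O)=O)c(F)c1` gives 2390 nM. Compound 3 `CCCCN(C)c1nc(C(F)(F)F)ccc1CNC(=O)C(C)c1ccc(NS(C)(=O)=O)c(F)c1` gives 21.3 nM, the lowest of the three numbers, and its steps from both other compounds lie beyond the scatter. Exchanging butylamino for dimethylamino on an aromatic carbon gave an 8.2-fold higher number from compound 1 to compound 2 (0.91 log units; beyond the scatter). Putting a methyl in place of hydrogen on a nitrogen on an aromatic ring gave a 14-fold lower number from compound 1 to compound 3 (1.14 log units; beyond the scatter), and putting propyl in place of hydrogen on a saturated chain carbon bound to that nitrogen gave a 110-fold lower number from compound 2 to compound 3 (2.05 log units; beyond the scatter).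

Compound 4 `CC(C(=O)NCc1ccc(C(F)(F)F)nc1N1CCC(c2ccccc2)CC1)c1ccc(NS(C)(=O)=O)c(F)c1` has not yet been measured. It differs from compound 3 by 4-phenylpiperidin-1-yl in place of butyl(methyl)amino on an aromatic carbon. Among the measured compounds shown here, the two large steps that arrive at compound 3 both bear on this change, since the nitrogen on the aromatic carbon again carries two carbon substituents, now tied together into a piperidine ring carrying a phenyl; no measured step covers a ring or a phenyl at this place, so the comparison is only partial. On the strength of those steps, compound 4 is expected to keep a low number in this assay, estimated at 20 nM, between 4 nM and 100 nM. That estimate would mean a 1.1-fold lower number from compound 3 to compound 4 (0.03 log units; within the scatter), expected to stay within the scatter.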

Compound 4, half-maximal inhibitory concentration: 25 nM
The estimate for compound 4 lay 1.3-fold (0.10 log units) below the measured number; the measured number falls inside the stated range.
By their numbers in this assay, from the lowest: compounds 3 and 4 (each within the scatter of the next); then compound 1; then compound 2.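

Read in this assay the aromatic carbon next to the ring nitrogen takes 4-phenylpiperidin-1-yl, with 12 heavy atoms and two rings, in place of butyl(methyl)amino, with 6 heavy atoms and no ring, and the result is a step within the scatter (a 1.2-fold higher number from compound 3 to compound 4 (0.07 log units; within the scatter)). The ring-and-phenyl group also stands far from the two other amino groups at this place, whether compared with dimethylamino (a 96-fold lower number from compound 2 to compound 4 (1.98 log units; beyond the scatter)) or with butylamino (a 12-fold lower number from compound 1 to compound 4 (1.07 log units; beyond the scatter)), so a low number here does not depend on an open chain on the nitrogen. No supporting measurement is available to explain why two such different groups give numbers within the scatter of each other.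

The compounds shown do not separate the share of the piperidine ring from that of the phenyl, which a plain piperidine or a pyrrolidine at the same carbon would address. They also leave open how a morpholine, a 4-benzylpiperidine or a hydroxyl or chlorine on the phenyl would read out at this place.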